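Removing the chloro: the same step on two cores

This account rests on a few compounds, and the source may have more. Where it says the series, first, only, none or still open, it means among the compounds named here.

Measured so far in a functional assay on A-375 cells (Homo sapiens) for antiproliferative activity, read by MTT assay, with a stated time of 72 h; a lower number here means a stronger inhibitor, a higher number a weaker inhibitor:
compound 1 `COc1ncc(-c2ccc3c(c2)N(c2ccccc2)C(=O)CO3)cc1NS(=O)(=O)c1ccc(F)cc1` — 15200 nM
compound 2 `COc1ncc(-c2ccc3c(c2)N(c2ccc(Cl)cc2)C(=O)CO3)cc1NS(=O)(=O)c1ccc(F)cc1` — 24100 nM
compound 3 `O=C1COc2ccc(-c3cnc4ccccc4c3)cc2N1c1ccc(Cl)cc1` — only a limit of this assay, > 40000 nM

Compound 2 and compound 1 share one core and differ by hydrogen in place of chloro on an aromatic carbon; in this assay the step is a 1.6-fold lower number from compound 2 to compound 1 (0.20 log units; within the scatter), so the two values cannot be ordered. Compound 3 carries a different core; how the core of compound 3 differs from that of compound 2 is not broken down here. For compound 3 the assay reports no number but a limit, (the limit of > 40000 nM in this assay, at which 1 of the 3 values shown sits).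

Compound 4 `O=C1COc2ccc(-c3cnc4ccccc4c3)cc2N1c1ccccc1` is not yet measured. It stands to compound 3 as compound 1 stands to compound 2, by hydrogen in place of chloro on an aromatic carbon, the same change at the same kind of place. Given that compound 3 is only a limit in this assay and that the measured step of a 1.6-fold lower number from compound 2 to compound 1 (0.20 log units; within the scatter) is within the scatter, the step to compound 4 is expected to be small, a step that the limit leaves unreadable from compound 3 to compound 4. Compound 4 is therefore estimated at 45000 nM in this assay, between 15000 nM and 150000 nM, with a fair chance that only a limit is again reported.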

Compound 4, half-maximal inhibitory concentration: > 40000 nM
Compound 4 gave a limit, no number; the forecaster's own chance of this, stated with the estimate: 60%; the middle value lies beyond the limit too.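

Compound 3 and compound 4 both stand only as limits in this assay, so no step between them can be read: the limit of > 40000 nM in this assay, at which 2 of the 4 values shown sit.

As far as these compounds go, what the 4-chlorophenyl to phenyl change does on the core of compound 3, and whether it matches the same change on the core of compound 2, stays open.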